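A few compounds are considered here, and "the series" means these few. Any claim that something is new, unique, unknown or untested is made for them only; others in the source may bear on it.

Measured so far:
- compound 1, `COc1ccc(Nc2nccs2)cc1OCC=C(C)C`: 42000 nM
- compound 2, `N#Cc1ccc(Nc2nccs2)cc1OCc1nccs1`: 20000 nM
- compound 3, `CSc1ccnc(Nc2ccc(Cl)c(OCC=C(C)C)c2)n1`: 2800 nM

All three values come from a functional assay on MT2 cells (Homo sapiens) for cytotoxicity, read by MTT assay; on this read-out higher numbers stand for lower toxicity in this test and lower numbers for higher toxicity in this test. Among the three, compound 3 gives the lowest number, and its gaps to compound 2 and to compound 1 both lie beyond the usual scatter, so within this set compound 3 is the most toxic in this assay. Compound 2 and compound 1 stand above it, with compound 1 giving the highest number of the three.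

The next compound, compound 4, is `CC(C)=CCOc1cc(Nc2nccc(CO)n2)ccc1Cl`. It keeps the core of compound 3 and differs from it in one place: hydroxymethyl in place of methylsulfanyl on an aromatic carbon. Going by the values given here, no pair of measured compounds differs in one place only, so there is no measured step to set against this change; what compound 4 will give must be read from compound 3 alone.

With only the value of compound 3 as anchor, a modest step is expected for compound 4 in this assay, leaning toward a higher number, though it may well stay within the scatter of the measurement of compound 3. The step from compound 3 to compound 4 is estimated at a 2.1-fold higher number from compound 3 to compound 4 (0.33 log units; beyond the scatter). Compound 4 is therefore expected to give about 6000 nM, with a likely range from 1500 nM to 25000 nM.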

Compound 4, half-maximal cytotoxic concentration: 220 nM
The estimate for compound 4 lay 27-fold (1.44 log units) above the measured number; measured number outside the range, below it.
By their numbers in this assay, from the lowest: compound 4; then compound 3; then compound 2; then compound 1.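

In this assay, the aromatic carbon next to the ring nitrogen proves sensitive to the group it carries: hydroxymethyl in place of methylsulfanyl gives a 13-fold lower number from compound 3 to compound 4 (1.10 log units; beyond the scatter), a large step toward higher toxicity in this test. The leaving and entering groups match in heavy atoms and in hydrogen-bond acceptors, and they differ in oxygen for sulfur and in the hydrogen-bond donor that hydroxymethyl brings, so an exchange of equal size in these counts is enough for a step of this size. Nothing at hand explains the step, and its cause stays unassigned.

This single pair cannot separate the contribution of the hydrogen-bond donor from that of oxygen replacing sulfur, and it does not show whether the step would carry over to another core, such as that of compound 1 or compound 2. Also open, on these data alone, is where methoxymethyl, which keeps the oxygen without the donor, aminomethyl, or a carboxylic acid on this same carbon would fall in this assay.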